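This account rests on a few compounds, and the source may have more. Where it says the series, first, only, none or still open, it means among the compounds named here.

Compound 3, `NC1=NC2(CCOCC2)N(OCCCOc2ccc(Cl)c(Cl)c2)C(N)=N1`, stands at the lowest number of the three compounds measured in an assay on isolated protein for inhibition of Dihydrofolate reductase (Homo sapiens), read by spectrophotometry, using NADPH, with stated times of 5 s and 6 min; on this read-out lower numbers stand for stronger inhibition and higher numbers for weaker inhibition: compound 3 gives 8.23 nM. Compound 1, `NC1=NC2(CCOCC2)N(OCCCOc2ccc(Cl)cc2)C(N)=N1`, gives 33.6 nM, and compound 2, `NC1=NC2(CCOCC2)N(OCCCOc2ccc(F)cc2)C(N)=N1`, gives 46.6 nM. The step of a 4.1-fold lower number from compound 1 to compound 3 (0.61 log units; beyond the scatter) and the step of a 5.7-fold lower number from compound 2 to compound 3 (0.75 log units; beyond the scatter) both run toward compound 3, while the step of a 1.4-fold higher number from compound 1 to compound 2 (0.14 log units; within the scatter) does not leave the scatter.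

Compound 4, `Cc1ccc(OCCCON2C(N)=NC(N)=NC23CCOCC3)cc1`, differs from compound 3 in one place: 4-methylphenyl in place of 3,4-dichlorophenyl on an oxygen on a saturated carbon. This change removes both chlorines of compound 3 and puts a 4-methylphenyl in their place. The two steps that bear on it point the same way. The step of a 4.1-fold lower number from compound 1 to compound 3 (0.61 log units; beyond the scatter) shows that taking away one chloro from compound 3 is accompanied by a modestly higher number, and the step of a 5.7-fold lower number from compound 2 to compound 3 (0.75 log units; beyond the scatter) shows much the same for the 4-fluorophenyl of compound 2. Since compound 4 carries neither chloro, a step back toward the numbers of compound 1 and compound 2 is expected, with the methyl left open. Compound 4 is therefore expected to show a modest rise in this assay, a 6.1-fold higher number from compound 3 to compound 4 (0.78 log units; beyond the scatter). For compound 4 the estimate is 50 nM, within a range from 20 nM to 130 nM.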

Compound 4, half-maximal inhibitory concentration: 56.8 nM
For compound 4 the middle estimate is 1.1-fold (0.06 log units) below the measured one, within the range that was stated.
By their numbers in this assay, from the lowest: compound 3; then compounds 1, 2 and 4 (each within the scatter of the next).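

In this assay, the 4-methylphenyl of compound 4 falls in with the groups of the two compounds that carry one halogen: a 1.2-fold higher number from compound 2 to compound 4 (0.09 log units; within the scatter) and a 1.7-fold higher number from compound 1 to compound 4 (0.23 log units; within the scatter) both stay within the scatter, so methyl, fluoro and chloro on this aromatic carbon cannot be told apart here. The 3,4-dichlorophenyl alone stands apart, with a 6.9-fold higher number from compound 3 to compound 4 (0.84 log units; beyond the scatter) lying beyond the scatter, so among these four compounds the lower number goes with that particular group and not with a chloro as such, since compound 1 also carries a chloro and does not share it. No measurement is at hand that explains why this group stands apart from the other three.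

The compounds shown leave open whether a second methyl or a second fluoro on the ring would match the second chloro, or whether the lower number belongs to the dichloro pattern alone. They also leave open how an amine or a carboxylic acid on the ring, or a longer chain in place of the present saturated chain, would stand in this assay.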